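Swapping the sulfur substituent in an anilide series

The source may hold more compounds than are shown below. What is called first, only, known or untested is meant among the compounds shown, and "the series" means these compounds.

Compound 1 `Cn1c(-c2ccc(NC(=O)CSc3nc4cc(Cl)ccc4o3)cc2)nc(-c2ccccc2)c1-c1ccccc1` and compound 2 `Cn1c(-c2ccc(NC(=O)CSC3=NCCS3)cc2)nc(-c2ccccc2)c1-c1ccccc1` share one core and differ only in the group attached to a sulfur. In a functional assay on HT-29 cells (Homo sapiens) for cytotoxicity, read by MTT assay, with a stated time of 24 h, tested at 1.6 ug/mL (a lower number here means a weaker effect, a higher number a stronger effect of the compound at the concentration tested), compound 1 gives 17.4%, while compound 2 gives 30.4%. Among the measured compounds shown here, the step of a number 13 percentage points higher from compound 1 to compound 2 (beyond the scatter) shows that replacing the larger bicyclic group by the five-membered non-aromatic ring raised the read-out, so compound 2 stands highest of the two measured numbers, with compound 1 as its only neighbour below it.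

Compound 3 `Cn1ccnc1SCC(=O)Nc1ccc(-c2nc(-c3ccccc3)c(-c3ccccc3)n2C)cc1` keeps the same core and again changes the group on that sulfur: a group of 6 heavy atoms (4 carbon, 2 nitrogen; one five-membered aromatic ring with 2 hetero atoms) in place of a group of 5 heavy atoms (3 carbon, 1 nitrogen, 1 sulfur; one five-membered non-aromatic ring with 2 hetero atoms), on a sulfur. For the measured compounds named here, the only measured step that bears on this place is the one from compound 1 to compound 2, and it was modest. Since the entering 1-methyl-1H-imidazol-2-yl group is a small five-membered aromatic ring rather than the large bicyclic group of compound 1, the account expects compound 3 to lie between its two neighbours, with the step of a number 6.4 percentage points lower from compound 2 to compound 3 (within the scatter) probably not reaching beyond the scatter. The estimate for compound 3 in this assay is 24%, within 12% to 36%.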

Compound 3, a percentage reported as activity, at one concentration (the size of the read-out at that concentration, not a potency): 23.8%
For compound 3 the middle estimate is 0.2 percentage points above the measured one; low and high end bracket the measured number.
By their numbers in this assay, from the lowest: compounds 1, 3 and 2 (each within the scatter of the next, the first and the last beyond it).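

With the third group on this sulfur, the difference between compound 1 and compound 2 no longer reads as a clean split between two kinds of substituent. In this assay, the change to 1-methyl-1H-imidazol-2-yl gives a number 6.6 percentage points lower from compound 2 to compound 3 (within the scatter), and set against the 5-chloro-1,3-benzoxazol-2-yl group it gives a number 6.4 percentage points higher from compound 1 to compound 3 (within the scatter), so compound 3 cannot be told apart from either neighbour, even though those two lie beyond the scatter of each other; an aromatic five-membered ring on this sulfur is thus separated neither from the non-aromatic ring nor from the larger bicyclic group. Nothing available explains these numbers, and no measurement of any property of these groups accompanies them.

The compounds shown all carry a ring on this sulfur, so it remains open how the read-out would respond to an open chain there, such as a longer alkyl chain or a chain ending in an amine or a carboxylic acid. Each compound also has a read-out at a single concentration only, which leaves open whether a stronger or weaker effect at that concentration would carry over to any other concentration.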